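The source may report more compounds than this note shows. Statements on the series, on what has been measured and on what is new or still open speak of the compounds shown alone.

Compounds measured:
compound 1, `Nc1n[nH]c2cc(-c3cccnc3)[nH]c(=O)c12` — 7%
compound 2, `Nc1n[nH]c2cc(-c3ccccn3)[nH]c(=O)c12` — 2%
compound 3, `CC(C)(C)c1cc2[nH]nc(N)c2c(=O)[nH]1` — 3%

Three compounds sharing one core were tested in an assay on isolated protein for inhibition of RAC-alpha serine/threonine-protein kinase (Homo sapiens), read by mobility shift assay, tested at 30 uM; a lower number here means less inhibition, a higher number more inhibition at the concentration tested (going by the name of the read-out). Compound 1 gives 7%, compound 2 gives 2% and compound 3 gives 3%. The three numbers sit close together: the gap from compound 2 to compound 3 and the gap from compound 2 to compound 1 both lie within the scatter of repeated measurements, so none of the three can be set apart from the others in this assay. All three readings are small.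

The next compound, compound 4, `Cn1nc(N)c2c(=O)[nH]c(-c3ccccn3)cc21`, differs from compound 2 in one place: methyl in place of hydrogen on an aromatic nitrogen. The methyl enters on an aromatic nitrogen of the five-membered aromatic ring with two nitrogens, within the fused system of two rings, two ring bonds from the ring atom that bears the amino group.

For the measured compounds named here, no pair of measured compounds shows the effect of this change, so there is nothing in the data to point to a step in either direction. The shared core has given only small readings across three different substituents, and compound 2 itself sits at 2%. The expected step from compound 2 to compound 4 is therefore a number 1 percentage points higher from compound 2 to compound 4 (within the scatter), that is, none beyond the scatter. Compound 4 is estimated to give 3% in this assay, with a range from -5% to 12%.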

Compound 4, a percentage reported as inhibition, at one concentration (the size of the read-out at that concentration, not a potency): 7%
Estimate against measurement, compound 4: 4 percentage points below; the range from low to high includes it.
By their numbers in this assay, from the lowest: compounds 2, 3, 1 and 4 (each within the scatter of the next).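

In this assay, for the compounds shown here, methyl in place of hydrogen on an aromatic nitrogen of the five-membered aromatic ring gives the only reading of this change at this position, a number 5 percentage points higher from compound 2 to compound 4 (within the scatter), so the methyl can be carried there without a reading that can be set apart from that of the parent compound. The result says little in either direction, as compound 2 gives only 2%, which leaves almost no room for a drop to show, while the step shows no gain beyond the scatter either. Nothing measured on these compounds offers an explanation for this step.

Still open, from the compounds shown here alone, is whether a larger group on this same aromatic nitrogen, such as a longer chain, a chain ending in an amine or one ending in a carboxylic acid, would lift the reading clear of the small numbers seen so far. Also open, going by these compounds, is whether the same methyl would leave the reading as little changed on the cores of compound 1 and compound 3, which carry other substituents.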